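Methyl on the amide nitrogen of compound 2

The source may report more compounds than this note shows. Statements on the series, on what has been measured and on what is new or still open speak of the compounds shown alone.

In a functional assay on MDA-MB-231 cells (Homo sapiens), read by microscopy and transwell migration, with a stated time of 24 h (a higher number here means a weaker inhibitor, a lower number a stronger inhibitor), compound 2 (`COc1cccc(C(=O)Nc2nc(-c3cc(OC)c(OC)c(OC)c3)cs2)c1`) gives 14000 nM and compound 1 (`COc1ccccc1C(=O)Nc1nc(-c2cc(OC)c(OC)c(OC)c2)cs1`) gives 8500 nM. For the measured compounds named here, the only measured step, a 1.6-fold higher number from compound 1 to compound 2 (0.22 log units; within the scatter), lies within the scatter, so compound 2 cannot be separated from its sole neighbour. Compound 3 (`COc1cccc(C(=O)N(C)c2nc(-c3cc(OC)c(OC)c(OC)c3)cs2)c1`) carries methyl in place of hydrogen on an amide-type nitrogen. Going by the values given here, the measured step concerns 3-methoxyphenyl in place of 2-methoxyphenyl on a carbonyl carbon, and no measured step touches this nitrogen, so the direction is only a tentative expectation. A lower number is expected in this assay, with an estimated step of a 4.7-fold lower number from compound 2 to compound 3 (0.67 log units; beyond the scatter). The expected value for compound 3 is 3000 nM, with an estimated range of 300 nM to 15000 nM.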

Compound 3, half-maximal inhibitory concentration: 646 nM
Beside the measured number, compound 3's estimate is 4.6-fold (0.67 log units) above it; the range from low to high includes it.
By their numbers in this assay, from the lowest: compound 3; then compounds 1 and 2 (each within the scatter of the next).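

Methyl in place of hydrogen on this amide-type nitrogen gives a 22-fold lower number from compound 2 to compound 3 (1.34 log units; beyond the scatter) in this assay and is the only change shown whose step lies beyond the scatter, unlike a 1.6-fold higher number from compound 1 to compound 2 (0.22 log units; within the scatter) on the carbonyl side. Activity in this series therefore does not depend on keeping the amide hydrogen, as compound 3 lacks it and still gives the lowest number. Nothing available bears on the reason for this large step.

Going by these compounds, whether ethyl or a longer chain on this nitrogen would lower the number further remains open. So does whether the same methyl would give a similar step on compound 1.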